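This account rests on a few compounds, and the source may have more. Where it says the series, first, only, none or still open, it means among the compounds named here.

Working notes on the series. In an ADME assay on MT4 cells (Homo sapiens) for cytotoxicity, with a stated time of 3 days (a higher number here means that more compound is tolerated, a lower number that less compound is tolerated), compound 1 `Cc1cc(/C=C/C#N)ccc1N(C)c1ccnc(Nc2ccc(C#N)cc2)n1` gives 11600 nM. Within the data shown here, compound 2 `CCc1cc(/C=C/C#N)cc(C)c1Nc1ccnc(Nc2ccc(C#N)cc2)n1` gives 2550 nM in this assay, the lower of the two numbers so far; the gap to compound 1 is beyond the usual scatter, so less of compound 2 is tolerated than of compound 1. Among the measured compounds shown here, no pair of measured compounds differs in a single place, so no single-point step is available to lean on.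

Compound 3 `COc1cc(/C=C/C#N)cc(C)c1Nc1ccnc(Nc2ccc(C#N)cc2)n1` is the next compound: methoxy in place of ethyl on an aromatic carbon. Nothing in the measured pair speaks to what a methoxy in place of an ethyl does at this position, and the change keeps the shared core, the 2-cyanoethenyl group and the methyl group of compound 2 untouched. The expectation is therefore for no step beyond the scatter in either direction, with the estimated move from compound 2 to compound 3 being a 1.4-fold higher number from compound 2 to compound 3 (0.14 log units; within the scatter). For compound 3 in this assay the estimate is 3500 nM, with a range from 1200 nM to 10000 nM.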

Compound 3, half-maximal cytotoxic concentration: 633 nM
For compound 3 the middle estimate is 5.5-fold (0.74 log units) above the measured one, and the stated range ends above it.
By their numbers in this assay, from the lowest: compound 3; then compound 2; then compound 1.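

Among these compounds, this is the first single-place step: in this assay, methoxy in place of ethyl on the aromatic carbon ortho to a large group gives a 4.0-fold lower number from compound 2 to compound 3 (0.61 log units; beyond the scatter), so less of compound 3 is tolerated than of compound 2. The position is therefore not indifferent to the group it carries, even though the groups that leave and enter have the same count of heavy atoms and differ only in one carbon given up for one oxygen and in the one hydrogen-bond acceptor that comes with it. No measurement at hand accounts for the size or direction of this step, so it stands as an observation on a single pair.

The compounds shown leave open whether the lower number follows the oxygen link itself or is particular to methoxy, a question that a hydroxyl, an amine or a longer chain such as propoxy at the same carbon would bear on. They also leave open whether the same exchange gives a step of similar size when the rest of the molecule differs from compound 2.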